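The source may report more compounds than this note shows. Statements on the series, on what has been measured and on what is new or still open speak of the compounds shown alone.

Compound 2 `Nc1ccccc1NC(=O)c1ccc(CSc2cccc(F)c2)cc1` gives 72.7% in a functional assay on A549 cells (Homo sapiens) for inhibition, read by CCK-8 assay, with a stated time of 72 h, tested at 8 uM (a lower number here means less inhibition of growth, a higher number more inhibition of growth at the concentration tested), the highest of the three numbers in hand; compound 3 `Nc1ccccc1NC(=O)/C=C/c1ccc(CSc2cccc3ccccc23)cc1` sits close with 71.2%, a gap that is within the scatter, while compound 1 `Cc1ccc(SCc2ccc(/C=C/C(=O)Nc3ccccc3N)cc2)cc1` lies well lower at 48.3%. Compound 4 `Nc1ccccc1NC(=O)c1ccc(CSc2ccc(Cl)cc2)cc1` has not yet been measured there. It differs from compound 2 in one place: 4-chlorophenyl in place of 3-fluorophenyl on a sulfur. Going by the values given here, only one measured step touches the same sulfur-bound group, namely a number 22.9 percentage points higher from compound 1 to compound 3 (beyond the scatter), which swaps one aromatic group for a larger one on the core of compound 1 rather than on the core of compound 2; it shows that changes at that position can move the number modestly, but it does not say in which direction a halogen moved from one ring position to another will act. Compound 4 is therefore expected to stay near compound 2, with a step of a number 4.7 percentage points lower from compound 2 to compound 4 (within the scatter) that may not exceed the scatter. The estimate for compound 4 in this assay is 68%, with a range from 50% to 82%.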

Compound 4, percent growth inhibition at one concentration: 50.4%
The estimate for compound 4 lay 17.6 percentage points above the measured number; low and high end bracket the measured number.
By their numbers in this assay, from the lowest: compounds 1 and 4 (each within the scatter of the next); then compounds 3 and 2 (each within the scatter of the next).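

In this assay, replacing 3-fluorophenyl with 4-chlorophenyl on the sulfur gives a number 22.3 percentage points lower from compound 2 to compound 4 (beyond the scatter), the first step shown on the core of compound 2. The earlier step at this sulfur, a number 22.9 percentage points higher from compound 1 to compound 3 (beyond the scatter), came with a change of aromatic group on another core, whereas here the number moves although the heavy-atom count and the hydrogen-bond donor and acceptor counts of the group stay the same. The halogen and its ring position change together in this step, and nothing shown bears on why the number falls.

The compounds shown leave open whether the halogen or its ring position carries the step. They also leave open how an unsubstituted phenyl or an aminophenyl on the same sulfur would read on the core of compound 2.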